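Working notes on the aryl group of the shared core

The compounds below may be only part of what the source reports. "The series", "measured", "known", "first", "only" and "open" are said of these compounds alone.

Compound 2 `COc1ccc(CNc2ncnc3c2ncn3[C@@H]2O[C@H](CO)[C@@H](O)[C@H]2O)c(OC)c1` carries a 2,4-dimethoxyphenyl on a saturated chain carbon bound to a nitrogen on an aromatic ring. In a functional assay on MCF cells (Homo sapiens) for antiproliferative activity, with a stated time of 72 h (a higher number here means a weaker inhibitor, a lower number a stronger inhibitor), compound 2 returns only a limit, > 166000 nM, so no number is known for it; this is the limit of > 166000 nM in this assay, at which 1 of the 3 values shown sits. Compound 1 `OC[C@H]1O[C@@H](n2cnc3c(NCc4cccc(F)c4)ncnc32)[C@H](O)[C@@H]1O`, with 3-fluorophenyl on a saturated chain carbon bound to a nitrogen on an aromatic ring, gives 15300 nM in this assay. The measured step of an at least 10-fold higher number from compound 1 to compound 2 (1.03 log units; beyond the scatter) is the only one bearing on the present change. Among the measured compounds shown here, compound 3 `COc1ccc(CNc2ncnc3c2ncn3C2OC(CO)[C@@H](O)[C@H]2O)c(O)c1` gives 2200 nM in this assay; no single-point step links it to compound 2 or compound 4, so its value stands alone.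

Compound 4 `OC[C@H]1O[C@@H](n2cnc3c(NCc4cccc(C(F)(F)F)c4)ncnc32)[C@H](O)[C@@H]1O` differs from compound 2 as follows: 3-(trifluoromethyl)phenyl in place of 2,4-dimethoxyphenyl on a saturated chain carbon bound to a nitrogen on an aromatic ring. The entering 3-(trifluoromethyl)phenyl is closer to the 3-fluorophenyl of compound 1 than to the departing 2,4-dimethoxyphenyl, and since the step from compound 1 to compound 2 was large and beyond the scatter, a large drop in this assay is expected for compound 4, back toward the region of compound 1. The expected step is an at least 8.3-fold lower number from compound 2 to compound 4 (0.91 log units; beyond the scatter). For compound 4 the estimate in this assay is 20000 nM, with a range from 5000 nM to 90000 nM.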

Compound 4, half-maximal inhibitory concentration: > 166000 nM
Compound 4: only a limit was reported (the forecaster's own chance of this, stated with the estimate: 20%); at least 8.3-fold (0.91 log units) between middle value and limit.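

Trifluoromethyl in place of fluoro on an aromatic carbon is a small change on paper, yet in this assay it gives an at least 10-fold higher number from compound 1 to compound 4 (1.03 log units; beyond the scatter) and so costs about as much readable activity as the full exchange of the aryl group did. The loss at this place on the saturated chain carbon is therefore not tied to the 2,4-dimethoxyphenyl of compound 2, since a single substituent swap on the 3-fluorophenyl of compound 1 is enough to produce it. Compound 4 returns only a limit, > 166000 nM in this case, the step linking it to compound 2 cannot be read, and the two aryl groups cannot be ranked against each other: the limit of > 166000 nM in this assay, at which 2 of the 4 values shown sit.

Going by these compounds, it remains open whether an unsubstituted phenyl, a 3-chlorophenyl or a 3-aminophenyl on the same carbon would hold the level of compound 1 or fall away as compound 4 does. Among the compounds shown here, compound 3 is the only compound here with a value clearly lower than that of compound 1, but no single-place step connects it to the others, so what its aryl group contributes stays unresolved.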